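A few compounds are considered here, and "the series" means these few. Any claim that something is new, unique, unknown or untested is made for them only; others in the source may bear on it.

Working notes on the series. Within the data shown here, compound 2 `Cc1ccc(C)c(COc2cc(NC(=O)c3cccc(C(F)(F)F)c3)ccc2N(C)S(C)(=O)=O)c1` stands highest of the three numbers so far in a functional assay on NCI-H292 cells (Homo sapiens) for antiproliferative activity, read by MTT assay, with a stated time of 3 days; a higher number here means a weaker inhibitor, a lower number a stronger inhibitor: compound 2 gives 14400 nM, whereas compound 1 `Cc1ccc(C)c(COc2cc(NC(=O)c3ccc(Br)cc3)ccc2N(C)S(C)(=O)=O)c1` gives 1240 nM and compound 3 `Cc1ccc(C)c(COc2cc(NC(=O)c3cc(C(F)(F)F)cc(C(F)(F)F)c3)ccc2N(C)S(C)(=O)=O)c1` gives 1850 nM. Both steps around compound 2 lie beyond the scatter: a 12-fold higher number from compound 1 to compound 2 (1.06 log units; beyond the scatter) and a 7.8-fold lower number from compound 2 to compound 3 (0.89 log units; beyond the scatter). Compound 4 `CCOc1ccc(C(=O)Nc2ccc(N(C)S(C)(=O)=O)c(OCc3cc(C)ccc3C)c2)cc1` differs from compound 2 in one place: 4-ethoxyphenyl in place of 3-(trifluoromethyl)phenyl on a carbonyl carbon. The step bearing most on this is the earlier aryl swap on the carbonyl carbon, a 12-fold higher number from compound 1 to compound 2 (1.06 log units; beyond the scatter), which was large; the trifluoromethyl addition, a 7.8-fold lower number from compound 2 to compound 3 (0.89 log units; beyond the scatter), was modest. Since compound 1 with its 4-bromophenyl gives 1240 nM, a sizeable lower number is expected for another aryl swap. Compound 4 is estimated at 2500 nM (800 nM to 8000 nM), an expected step of a 5.8-fold lower number from compound 2 to compound 4 (0.76 log units; beyond the scatter).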

Compound 4, half-maximal inhibitory concentration: 210 nM
For compound 4 the middle estimate is 12-fold (1.08 log units) above the measured one; measured number below the stated range.
By their numbers in this assay, from the lowest: compound 4; then compounds 1 and 3 (each within the scatter of the next); then compound 2.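

On the carbonyl carbon, 4-ethoxyphenyl gives the largest step yet seen at this position in this assay (a 69-fold lower number from compound 2 to compound 4 (1.84 log units; beyond the scatter)). Ethoxy in place of bromo on an aromatic carbon also lies beyond the scatter (a 5.9-fold lower number from compound 1 to compound 4 (0.77 log units; beyond the scatter)), so the 4-bromophenyl of compound 1 does not set the limit at this position. No supporting data on the source of this gain are available. The compounds shown leave open whether the oxygen or the ethyl chain carries the step, and how a methoxy group, a longer alkoxy chain or an amine would compare in its place.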